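From Butyl to Isobutyl on a Sulfur-Bound Chain

The source may hold more compounds than are shown below. What is called first, only, known or untested is meant among the compounds shown, and "the series" means these compounds.

Compound 1 `CCC[S+]([O-])CCCCN=C=S`: 5960 nM
Compound 2 `CCCC[S+]([O-])CCCCN=C=S`: 5840 nM

In a functional assay on MCF7 cells (Homo sapiens) for cytotoxicity, read by MTT assay, with a stated time of 72 h (on this read-out lower numbers stand for stronger inhibition and higher numbers for weaker inhibition), compound 2 gives 5840 nM. Compound 1 gives 5960 nM, and the two values lie within the usual scatter of each other, so neither can be ranked above the other.

The next compound to be tested is compound 3 `CC(C)C[S+]([O-])CCCCN=C=S`. The change is isopropyl in place of propyl on a saturated chain carbon bound to a sulfur. In plain words, isopropyl takes the place of propyl on a saturated chain carbon bound to a sulfur, which can also be read as butyl becoming isobutyl.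

Among the measured compounds shown here, only one measured step bears on this change: a 1.0-fold lower number from compound 1 to compound 2 (0.01 log units; within the scatter). That step put methyl in place of hydrogen on the chain and stayed within the scatter. For the measured compounds named here, it is a loose guide, since no measured compound carries an isobutyl group. No shift beyond the scatter, in either direction, is therefore expected in this assay.

The expected step is a 1.0-fold higher number from compound 2 to compound 3 (0.00 log units; within the scatter).

For compound 3 the estimated value is 5900 nM, with an expected range from 3500 nM to 10000 nM.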

Compound 3, half-maximal inhibitory concentration: 3660 nM
For compound 3 the middle estimate is 1.6-fold (0.21 log units) above the measured one; the measured number falls inside the stated range.
By their numbers in this assay, from the lowest: compounds 3, 2 and 1 (each within the scatter of the next).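

Swapping propyl for isopropyl on a saturated chain carbon bound to a sulfur rearranges the same atoms without adding any, and in this assay this gives a result that is no real difference (a 1.6-fold lower number from compound 2 to compound 3 (0.20 log units; within the scatter)). The second comparison tests a new place, with methyl in place of hydrogen on a saturated chain carbon bound to two saturated chain carbons, and it also stays within the usual scatter (a 1.6-fold lower number from compound 1 to compound 3 (0.21 log units; within the scatter)), so adding a carbon at either of these two places on the chain has shown no clear effect. No supporting measurement is available to explain this outcome.

On these data alone, these three compounds cover only a narrow set of small saturated chains, so it remains open whether the same flat picture would hold for a longer chain such as octyl, for a ring such as cyclohexyl or phenyl, or for a chain carrying an amine or a carboxylic acid. Whether the three compounds would also stay this close in a different cell line is likewise unanswered.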